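A few compounds are considered here, and "the series" means these few. Any claim that something is new, unique, unknown or untested is made for them only; others in the source may bear on it.

Measured so far:
- compound 1, `CC1=CC[C@H]2[C@H](CC[C@]2(C)O)C(C)(C)[C@@H]1CC[C@H]1[C@]2(C)CC[C@H](OC(=O)c3ccncc3)C(C)(C)O[C@H]2CC[C@@]1(C)O`, this assay: 18000 nM
- compound 2, `CC1=CC[C@H]2[C@H](CC[C@]2(C)O)C(C)(C)[C@@H]1CC[C@H]1[C@]2(C)CC[C@H](OC(=O)c3ccc(C)cc3)C(C)(C)O[C@H]2CC[C@@]1(C)O`, this assay: 33400 nM
- compound 3, `CC1=CC[C@H]2[C@@H]1CC=C(C)[C@@H](CC[C@H]1[C@]3(C)CC[C@H](OC(=O)c4ccncc4)C(C)(C)O[C@H]3CC[C@@]1(C)O)C2(C)C`, this assay: 19100 nM

All three numbers come from a functional assay on MDA-MB-231 cells (Homo sapiens) for antiproliferative activity, read by MTT assay, with a stated time of 72 h; a higher number here means a weaker inhibitor, a lower number a stronger inhibitor. Compound 1 and compound 3 share the same ester group on a core that differs between them; how the two cores differ is not broken down here. Compound 2 is made from compound 1 by one change, (4-methylphenyl in place of pyridin-4-yl on a carbonyl carbon), and that change gives a 1.9-fold higher number from compound 1 to compound 2 (0.27 log units; within the scatter).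

Compound 4, `CC1=CC[C@H]2[C@@H]1CC=C(C)[C@@H](CC[C@H]1[C@]3(C)CC[C@H](OC(=O)c4ccc(C)cc4)C(C)(C)O[C@H]3CC[C@@]1(C)O)C2(C)C`, is not yet measured. It stands to compound 3 as compound 2 stands to compound 1: the change is 4-methylphenyl in place of pyridin-4-yl on a carbonyl carbon, at the same place, so it is the same change carried onto the core of compound 3. Among the compounds with values here, compound 3 gives 19100 nM, a number close to that of compound 1, so the one step already seen is the only guide. Within the data shown here, for compound 4 the expected step is a 1.7-fold higher number from compound 3 to compound 4 (0.24 log units; within the scatter), resting on the single earlier step from compound 1 to compound 2, which the scatter could swallow. The estimate for compound 4 in this assay is 33000 nM, expected to fall between 14000 nM and 75000 nM.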

Compound 4, half-maximal inhibitory concentration: 32700 nM
Beside the measured number, compound 4's estimate is 1.0-fold (0.00 log units) above it; measured number inside the range.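

In this assay, 4-methylphenyl in place of pyridin-4-yl on a carbonyl carbon gives a 1.7-fold higher number from compound 3 to compound 4 (0.23 log units; within the scatter). The change carries from one core to the other with no difference that these data can separate: the same change on two cores in this assay, a 1.9-fold higher number (0.27 log units; within the scatter) from compound 1 to compound 2 and a 1.7-fold higher number (0.23 log units; within the scatter) from compound 3 to compound 4, 1.1-fold (0.03 log units) apart, within the scatter of two such steps. Each step lies within the scatter on its own, so the result shows agreement between two small steps; it does not show that the change truly shifts the number on either core, or that the agreement would hold on any other core.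

The compounds shown cover only two aromatic groups on the carbonyl carbon, so it remains open whether an amine or a longer carbon chain in place of the aromatic ring would give a step beyond the scatter. Also open, as far as these compounds go, is whether a step of that size would then carry between the two cores as closely as this one does.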